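Replacing the thiophene amine with a methoxy-phenylethylamine

The compounds below may be only part of what the source reports. "The series", "measured", "known", "first", "only" and "open" are said of these compounds alone.

Compounds measured so far:
- compound 1 `c1ccc(CNCC2CCN(CCCc3c[nH]c4ccc(-n5cnnc5)cc34)CC2)cc1`: 101%
- compound 2 `OC[C@H](NC1CCN(CCCc2c[nH]c3ccc(-n4ccnc4)cc23)CC1)c1ccccc1`: 74%
- compound 3 `CN(Cc1cccs1)C1CCN(CCCc2c[nH]c3ccc(-n4cnnc4)cc23)CC1`: 81%

In a functional assay on CHO cells for activation of 5-hydroxytryptamine receptor 1D (Homo sapiens), read by GTPgammaS binding (a higher number here means a larger maximal response, a lower number a smaller maximal response), compound 3 gives 81%, the second highest of the three numbers. Its nearest neighbour is compound 2 with 74%, a gap within the scatter, so the two cannot be ordered. Compound 1, with 101%, stands further away; the step of a number 20 percentage points lower from compound 1 to compound 3 (beyond the scatter) lies beyond the scatter.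

Compound 4 `COC[C@H](NC1CCN(CCCc2c[nH]c3ccc(-n4cnnc4)cc23)CC1)c1ccccc1` keeps the shared core of compound 3 and differs only in the amine attached to the saturated ring: (2-methoxy-1-phenylethyl)amino in place of methyl((thiophen-2-yl)methyl)amino on a saturated ring carbon.

Going by the values given here, only one measured step touches this position, a number 20 percentage points lower from compound 1 to compound 3 (beyond the scatter), and it moved by a modest amount while converting a secondary amine into a tertiary one. Compound 4 returns to a secondary amine bearing a phenyl group, which resembles compound 1; at the same time its 2-methoxy-1-phenylethyl group is close to the hydroxymethyl analogue in compound 2, whose value sits within the scatter of compound 3. A small rise in this assay is therefore expected, though an unchanged result would not surprise: the expected step is a number 3 percentage points higher from compound 3 to compound 4 (within the scatter). Compound 4 is estimated at 84%, with a range from 66% to 102%.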

Compound 4, largest response reached (reported as efficacy), in percent of the reference or control that the assay uses: 93%
For compound 4 the middle estimate is 9 percentage points below the measured one, within the range that was stated.
By their numbers in this assay, from the lowest: compounds 2 and 3 (each within the scatter of the next); then compounds 4 and 1 (each within the scatter of the next).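

In this assay, exchanging methyl((thiophen-2-yl)methyl)amino for (2-methoxy-1-phenylethyl)amino gives a number 12 percentage points higher from compound 3 to compound 4 (beyond the scatter), so this position on the saturated ring carbon can move the maximal response up as well as down, which the earlier step alone did not show. The comparison with the other high compound gives a number 8 percentage points lower from compound 1 to compound 4 (within the scatter), so compound 1 and compound 4 cannot be ordered, and two quite different groups at this place, (benzylamino)methyl and (2-methoxy-1-phenylethyl)amino, give responses that cannot be told apart. The change from compound 3 to compound 4 alters the aromatic ring, the number of hydrogen-bond donors and the presence of a defined stereocentre all at once, and nothing available here separates these or explains the rise.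

Still open, as far as these compounds go, is what the methoxy group itself contributes, which a plain (1-phenylethyl)amino group at this place would test. The compounds shown also leave open how the opposite mirror-image form of the stereocentre, or an N-methyl version of the (2-methoxy-1-phenylethyl)amino group, would behave.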